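The source may report more compounds than this note shows. Statements on the series, on what has been measured and on what is new or still open speak of the compounds shown alone.

Compound 1 `CCCCOc1ccc(C(=O)Nc2cccc(C(=O)O)c2)cc1` is the stronger of the two measured compounds: in an assay on isolated protein for agonist activity at Bile acid receptor (Homo sapiens), read by TR-FRET, with a stated time of 3 h, in the absence of a further agent (on this read-out lower numbers stand for an effect already at smaller amounts and higher numbers for an effect only at larger amounts of compound), compound 1 gives 105 nM, while compound 2 `CC(C)CCOc1cccc(C(=O)Nc2cccc(C(=O)O)c2)c1` gives 2760 nM in this assay, a gap beyond the scatter. Compound 2 is not tied to compound 1 by a single change. Compound 3 `CC(C)CCOc1ccc(C(=O)Nc2cccc(C(=O)O)c2)cc1` differs from compound 1 by methyl in place of hydrogen on a saturated chain carbon bound to two saturated chain carbons, the butyl chain becoming an isopentyl chain. Going by the values given here, with no single-change step measured, the expected step from compound 1 to compound 3 is small, a 1.4-fold higher number from compound 1 to compound 3 (0.15 log units; within the scatter), not beyond the scatter. Compound 3 is therefore estimated at 150 nM in this assay, within 50 nM to 500 nM.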

Compound 3, half-maximal effective concentration: 215 nM
Estimate against measurement, compound 3: 1.4-fold (0.16 log units) below; the range from low to high includes it.
By their numbers in this assay, from the lowest: compound 1; then compound 3; then compound 2.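

In this assay the added methyl on the saturated chain carbon is not silent, with a 2.0-fold higher number from compound 1 to compound 3 (0.31 log units; beyond the scatter) as a modest cost. The isopentyl chain still permits a low number, since compound 3 gives 215 nM while compound 2, which carries the same chain, gives 2760 nM on this read-out. Going by these compounds, how a longer chain, a propyl chain or an amine at the chain end would read stays open. Nothing measured here bears on what lies behind this step.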